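From Methyl to 2-Hydroxyethoxy on a Shared Core

The source may hold more compounds than are shown below. What is called first, only, known or untested is meant among the compounds shown, and "the series" means these compounds.

In a functional assay on MCF7 cells (Homo sapiens) for inhibition, with a stated time of 48 h (a lower number here means a stronger inhibitor, a higher number a weaker inhibitor), compound 1 `COc1cc(Sc2c[nH]c3ccccc23)cc(OC)c1OC` gives 34 nM. Compound 2 `COc1cc(Sc2c[nH]c3ccc(F)cc23)cc(OC)c1OC`, which carries fluoro, gives 160 nM. Compound 3 `COc1cc(Sc2c[nH]c3ccc(C)cc23)cc(OC)c1OC`, which carries methyl, gives 16 nM, the lowest of the three numbers. Its steps to both other compounds lie beyond the scatter.

Compound 4 `COc1cc(Sc2c[nH]c3ccc(OCCO)cc23)cc(OC)c1OC` has not yet been measured. It has 2-hydroxyethoxy in place of methyl on an aromatic carbon.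

Three measured steps at this carbon bear on the change. Fluoro in place of hydrogen gives a 4.7-fold higher number from compound 1 to compound 2 (0.67 log units; beyond the scatter), methyl in place of hydrogen gives a 2.1-fold lower number from compound 1 to compound 3 (0.33 log units; beyond the scatter), and methyl in place of fluoro gives a 10-fold lower number from compound 2 to compound 3 (1.00 log units; beyond the scatter). Small replacements here thus shift the number in either direction, and no measured compound carries a comparable chain, so the direction remains uncertain. Starting from the lowest number, a modest upward move is expected, smaller than the largest measured step, with the estimate being a 5.0-fold higher number from compound 3 to compound 4 (0.70 log units; beyond the scatter). For compound 4, the estimated value is 80 nM, with an expected range of 20 nM to 320 nM.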

Compound 4, half-maximal inhibitory concentration: 95 nM
For compound 4 the middle estimate is 1.2-fold (0.07 log units) below the measured one, and the stated range covers the measured number.
By their numbers in this assay, from the lowest: compound 3; then compound 1; then compounds 4 and 2 (each within the scatter of the next).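

In this assay, among these compounds, 2-hydroxyethoxy is the first group at this aromatic carbon to bring a hydrogen-bond donor, and replacing methyl with it loses the advantage that methyl held (a 5.9-fold higher number from compound 3 to compound 4 (0.77 log units; beyond the scatter)). Replacing fluoro with the same chain gives a step within the scatter (a 1.7-fold lower number from compound 2 to compound 4 (0.23 log units; within the scatter)), so two very different groups cannot be told apart at this position. Relative to hydrogen, the chain also gives a higher number (a 2.8-fold higher number from compound 1 to compound 4 (0.45 log units; beyond the scatter)), which leaves methyl as the only replacement shown that gives a lower number than hydrogen.

Nothing given here accounts for these differences. The compounds shown leave open whether the terminal hydroxyl or the chain itself sets the result, a question that methoxy, 2-methoxyethoxy or an amine-ended chain at the same carbon could address.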